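This account rests on a few compounds, and the source may have more. Where it says the series, first, only, none or still open, it means among the compounds named here.

Four close relatives are compared here in a functional assay on HT-29 cells (Homo sapiens) for antiproliferative activity, read by MTT assay, with a stated time of 72 h; on this read-out lower numbers stand for stronger inhibition of growth and higher numbers for weaker inhibition of growth. Compound 1 `Cc1ccc2nc(-c3ccc([N+](=O)[O-])cc3)cn2c1` carries a nitro group on its pendant carbon ring, and compound 2 `Cc1ccc2nc(-c3ccc(N)cc3)cn2c1` is the same molecule with that nitro group exchanged for an amino group, the change being (amino in place of nitro on an aromatic carbon). In this assay compound 1 gives only a limit, > 100000 nM. Compound 2 gives 82900 nM in this assay. The step between the two is an at least 1.2-fold lower number from compound 1 to compound 2 (0.08 log units; that floor lies within the scatter), and it cannot be sized more closely because of the limit of > 100000 nM in this assay, at which 2 of the 3 values shown sit.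

Compound 3 `Cc1ccn2cc(-c3ccc([N+](=O)[O-])cc3)nc2c1` is built from the same atoms as compound 1, joined differently; the difference between the two cores is not broken down here. In this assay compound 3 gives only a limit, > 100000 nM. Compound 4 `Cc1ccn2cc(-c3ccc(N)cc3)nc2c1` has not yet been measured and differs from compound 3 by the same change seen between compound 1 and compound 2: amino in place of nitro on an aromatic carbon.

Since the pair of compound 1 and compound 2 shows only a small and uncertain step from nitro to amino, and since compound 3 sits at the assay limit like compound 1, the step from compound 3 to compound 4 is expected to be small as well, an at least 1.1-fold lower number from compound 3 to compound 4 (0.04 log units; that floor lies within the scatter). On that basis compound 4 is estimated in this assay at about 90000 nM, most likely between 40000 nM and 200000 nM, with a fair chance that it again returns only a limit.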

Compound 4, concentration for 50% growth inhibition: 93600 nM
Beside the measured number, compound 4's estimate is 1.0-fold (0.02 log units) below it; low and high end bracket the measured number.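

In this assay, exchanging nitro for amino on the core of compound 3 gives an at least 1.0-fold lower number from compound 3 to compound 4 (0.02 log units; that floor lies within the scatter). Set side by side, the two cores give this picture: the same change on two cores in this assay, an at least 1.2-fold lower number (0.08 log units; that floor lies within the scatter) from compound 1 to compound 2 and an at least 1.0-fold lower number (0.02 log units; that floor lies within the scatter) from compound 3 to compound 4; the limit leaves it open whether they differ. The result fits a change that carries over in a limited sense, since on each core the nitro compound gives only a limit and the amino compound gives a number, yet it does not show that the step has the same size on both cores, or how large either step really is: the limit of > 100000 nM in this assay, at which 2 of the 4 values shown sit.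

The compounds shown leave open how the true numbers of the two nitro compounds compare with those of their amino partners, since a limit marks only where the measurement ends and not where the compound itself stands. They also leave open whether a different group in the same place on the carbon ring, such as a hydroxyl, a methoxy, an acetamide or a dimethylamino group, would bring the number down by a step clearly beyond the scatter on either core.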